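This account rests on a few compounds, and the source may have more. Where it says the series, first, only, none or still open, it means among the compounds named here.

Compound 1 `COC(=O)c1ccc(NC(=O)C2(C(=O)Nc3ccc(Nc4ncc5cc(C(=O)N(C)C)n(C6CCCC6)c5n4)cc3)CC2)cc1` gives 77.1% in a functional assay on A549 cells (Homo sapiens) for inhibition, read by CCK-8 assay, with a stated time of 72 h, tested at 1 uM; a lower number here means less inhibition of growth, a higher number more inhibition of growth at the concentration tested. Compound 2 `COc1ccc(NC(=O)C2(C(=O)Nc3ccc(Nc4ncc5cc(C(=O)N(C)C)n(C6CCCC6)c5n4)cc3)CC2)cc1` gives 74.4%.

Compound 2 stands lowest of the two numbers in this assay, with compound 1 nearest, and the step of a number 2.7 percentage points lower from compound 1 to compound 2 (within the scatter) is within the scatter. Compound 3 `CN(C)C(=O)c1cc2cnc(Nc3ccc(NC(=O)C4(C(=O)Nc5ccccc5)CC4)cc3)nc2n1C1CCCC1` has not yet been measured in this assay. It differs from compound 2 in one place: hydrogen in place of methoxy on an aromatic carbon. Among the measured compounds shown here, no measured step bears directly on removing a methoxy group; the only measured step exchanges one group for another on the same aromatic carbon and gives a change within the scatter. That step suggests the substituent on this ring contributes little to the read-out within the pair shown, so compound 3 is expected to lie close to compound 2, with a step of about a number 2.4 percentage points lower from compound 2 to compound 3 (within the scatter) and no change beyond the scatter. Compound 3 is estimated at 72%, within a range from 58% to 82%.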

Compound 3, percent growth inhibition at one concentration: 75%
For compound 3 the middle estimate is 3 percentage points below the measured one, and the stated range covers the measured number.
By their numbers in this assay, from the lowest: compounds 2, 3 and 1 (each within the scatter of the next).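

In this assay, removing the methoxy group altogether gives a number 0.6 percentage points higher from compound 2 to compound 3 (within the scatter), and replacing the methoxycarbonyl group with hydrogen gives a number 2.1 percentage points lower from compound 1 to compound 3 (within the scatter). The earlier step only exchanged one substituent for another, whereas these steps add the unsubstituted phenyl group to the comparison and show that, among these three compounds, a substituent at this place, para to a large group, does not separate the read-out from hydrogen beyond the scatter. No evidence is available that bears on this result.

The compounds shown leave open whether an amine or a carboxylic acid at this place would move the number beyond the scatter. As far as these compounds go, whether the three compounds would stay together at other concentrations also remains open.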